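Replacing a benzylamide with a pyrrolidine amide

This account rests on a few compounds, and the source may have more. Where it says the series, first, only, none or still open, it means among the compounds named here.

Three compounds have been measured in a functional assay on A549 cells (Homo sapiens) for antiproliferative activity, read by CCK-8 assay, with a stated time of 48 h; a higher number here means a weaker inhibitor, a lower number a stronger inhibitor:

compound 1, `CNC(=O)c1cc(Oc2ccc(/C=C/c3ccncc3)cc2)ccn1`, 13200 nM
compound 2, `O=C(NCc1ccccc1)c1cc(Oc2ccc(/C=C/c3ccncc3)cc2)ccn1`, 17000 nM
compound 3, `O=C(NCc1ccc(F)cc1)c1cc(Oc2ccc(/C=C/c3ccncc3)cc2)ccn1`, 18200 nM

The three numbers lie close together. The step of a 1.3-fold higher number from compound 1 to compound 2 (0.11 log units; within the scatter) and the step of a 1.4-fold higher number from compound 1 to compound 3 (0.14 log units; within the scatter) both stay within the usual scatter, and so does the step of a 1.1-fold higher number from compound 2 to compound 3 (0.03 log units; within the scatter). Compound 3 therefore stands within the scatter of both compound 1 and compound 2; none of the three can be called stronger or weaker than another.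

Compound 4, `O=C(c1cc(Oc2ccc(/C=C/c3ccncc3)cc2)ccn1)N1CCCC1`, has not been measured. It differs from compound 3 by pyrrolidin-1-yl in place of (4-fluorobenzyl)amino on a carbonyl carbon. For the measured compounds named here, no measured step covers this exact change, since the amide hydrogen is kept in every measured compound. What the measured steps do show is that changing the group on the saturated chain carbon bound to the amide-type nitrogen, from hydrogen to phenyl or to 4-fluorophenyl, moved the number only within the scatter. On that basis compound 4 is expected to land near the others, with a step of a 1.2-fold lower number from compound 3 to compound 4 (0.08 log units; within the scatter) that is not expected to exceed the scatter. The estimate for compound 4 is 15000 nM, with a range from 6000 nM to 40000 nM.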

Compound 4, half-maximal inhibitory concentration: 18600 nM
Compound 4: the middle estimate sits 1.2-fold (0.09 log units) below what was measured, and the stated range covers the measured number.
By their numbers in this assay, from the lowest: compounds 1, 2, 3 and 4 (each within the scatter of the next).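

For the compounds shown here, the amide hydrogen, present in all the earlier compounds, is absent from compound 4, yet in this assay the result stays within the scatter: a 1.0-fold higher number from compound 3 to compound 4 (0.01 log units; within the scatter) with the (4-fluorobenzyl)amino group replaced, a 1.1-fold higher number from compound 2 to compound 4 (0.04 log units; within the scatter) with the benzylamino group replaced, and a 1.4-fold higher number from compound 1 to compound 4 (0.15 log units; within the scatter) with the methylamino group replaced. On this carbonyl carbon, then, neither the amide hydrogen nor an aromatic ring in the group is needed to hold the number at this level in these four compounds. Nothing available explains this outcome.

The compounds shown leave open whether any group on this carbonyl carbon can move the number beyond the scatter. A carboxylic acid in place of the amide, a piperazin-1-yl ring, or a longer chain ending in an amine would each test this.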